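From Dimethylphenyl Amide to Plain Phenyl Amide

The compounds below may be only part of what the source reports. "The series", "measured", "known", "first", "only" and "open" are said of these compounds alone.

Compound 1, `CC(=O)c1ccc(NC(=O)/C=C/C(=O)N2C/C(=C\c3ccc([N+](=O)[O-])cc3)C(=O)/C(=C/c3ccc([N+](=O)[O-])cc3)C2)cc1`: 390 nM
Compound 2, `O=C(/C=C/C(=O)N1C/C(=C\c2ccc([N+](=O)[O-])cc2)C(=O)/C(=C/c2ccc([N+](=O)[O-])cc2)C1)Nc1ccc(Cl)cc1`: 1200 nM
Compound 3, `Cc1ccc(NC(=O)/C=C/C(=O)N2C/C(=C\c3ccc([N+](=O)[O-])cc3)C(=O)/C(=C/c3ccc([N+](=O)[O-])cc3)C2)cc1C`: 660 nM

The three measured compounds share one core and differ only in the aryl group carried by the amide-type nitrogen, and all three were tested in a functional assay on Molt4/C8 cells (Homo sapiens) for cytotoxicity; a higher number here means a weaker inhibitor, a lower number a stronger inhibitor. Compound 3 stands second highest of the three numbers; its nearest neighbour is compound 1 and its furthest is compound 2, yet both of those gaps lie within the scatter. Going by the values given here, the only step beyond the scatter is a 3.1-fold higher number from compound 1 to compound 2 (0.49 log units; beyond the scatter), which is modest.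

Compound 4, `O=C(/C=C/C(=O)N1C/C(=C\c2ccc([N+](=O)[O-])cc2)C(=O)/C(=C/c2ccc([N+](=O)[O-])cc2)C1)Nc1ccccc1`, differs from compound 3 by phenyl in place of 3,4-dimethylphenyl on an amide-type nitrogen. Among the compounds with values here, the steps that bear on this change are a 1.7-fold higher number from compound 1 to compound 3 (0.23 log units; within the scatter) and a 1.8-fold lower number from compound 2 to compound 3 (0.26 log units; within the scatter); both swap one aryl group for another on the same nitrogen and both stay within the scatter. The record thus shows that exchanging the aryl group here moves this assay little, and at most modestly. For compound 4 no step beyond the scatter is therefore expected in this assay, with a wide range to allow for a modest move either way. The expected step is a 1.1-fold higher number from compound 3 to compound 4 (0.03 log units; within the scatter). Compound 4 is estimated at 700 nM, within a range from 300 nM to 1600 nM.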

Compound 4, half-maximal inhibitory concentration: 360 nM
For compound 4 the middle estimate is 1.9-fold (0.29 log units) above the measured one, within the range that was stated.
By their numbers in this assay, from the lowest: compounds 4, 1, 3 and 2 (each within the scatter of the next, the first and the last beyond it).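

In this assay, phenyl in place of 3,4-dimethylphenyl on the amide-type nitrogen gives a 1.8-fold lower number from compound 3 to compound 4 (0.26 log units; within the scatter) and removing the acetyl group gives a 1.1-fold lower number from compound 1 to compound 4 (0.03 log units; within the scatter) so neither the 3,4-dimethylphenyl nor the 4-acetylphenyl group sets its compound apart from the plain phenyl amide. Hydrogen in place of chloro on an aromatic carbon gives a 3.3-fold lower number from compound 2 to compound 4 (0.52 log units; beyond the scatter) and this is a second modest step beyond the scatter with the 4-chlorophenyl amide at one end, although compound 3 stays within the scatter of both compound 2 and compound 4, so the four compounds do not fall into two clean groups. Nothing in the record accounts for this step.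

The compounds shown leave open how an amine, a carboxylic acid or a bromine atom in place of the chloro on that aromatic carbon would read in this assay and whether any such group would move the number further than the chloro does. They also leave open what a longer alkyl chain in place of the aryl group on the amide-type nitrogen would do.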